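Dropping the ethyl group from compound 1

A few compounds are considered here, and "the series" means these few. Any claim that something is new, unique, unknown or untested is made for them only; others in the source may bear on it.

In a functional assay (strain AB) with Danio rerio as the target, read by microscopy, with a stated time of 1 h (on this read-out lower numbers stand for an effect already at smaller amounts and higher numbers for an effect only at larger amounts of compound), compound 1 (`CCC1CCc2c(sc(NC(=O)Nc3ccc(Cl)cc3)c2C(N)=O)C1`) gives > 25000 nM, which is a limit of the assay and not a number. Compound 2 (`CCN1CCc2c(sc(NC(=O)Nc3ccccc3)c2C(N)=O)C1`) gives > 25000 nM, which is likewise a limit. That makes (the limit of > 25000 nM in this assay, at which 2 of the 3 values shown sit), so compound 1 stands with the majority of this small set. For the measured compounds named here, compound 3 (`CCN1CCc2sc(NC(=O)Nc3ccc(Cl)cc3)c(C(N)=O)c2CC1`) is the only one with a true number, 5800 nM.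

Compound 4 (`NC(=O)c1c(NC(=O)Nc2ccc(Cl)cc2)sc2c1CCCC2`) has not yet been measured. It has hydrogen in place of ethyl on a saturated ring carbon, and the counted difference from compound 1 is hydrogen in place of ethyl on a saturated ring carbon. Going by the values given here, no measured pair isolates this change, so any forecast is uncertain. The expectation leans on compound 3, whose 5800 nM shows that a compound of this kind can give a number in this assay. A moderate move toward lower numbers is expected, although a result at the limit remains quite possible. The estimated step is an at least 2.7-fold lower number from compound 1 to compound 4 (0.44 log units; beyond the scatter). Compound 4 is expected at about 9000 nM, with an estimated range of 2500 nM to 25000 nM.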

Compound 4, half-maximal effective concentration: > 25000 nM
Compound 4: only a limit was reported; the forecaster's own chance of this, stated with the estimate: 35%; middle value at least 2.7-fold (0.44 log units) from the limit.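

In this assay, for the compounds shown here, compound 4 gives > 25000 nM, a limit and not a number, and compound 1 also sits at a limit, so no step between them can be read. On these data alone, whether hydrogen in place of ethyl on the saturated ring carbon changes the effect at all stays open.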